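This account rests on a few compounds, and the source may have more. Where it says the series, first, only, none or still open, it means among the compounds named here.

In a toxicity assay on HT-29 cells (Homo sapiens) for cytotoxicity (a higher number here means that more compound is tolerated, a lower number that less compound is tolerated), compound 1 `CCCCn1nc(C(=O)N[C@H]2COc3ccccc3N(C)C2=S)nc1Cc1ccccc1` gives > 100000 nM, a limit of the assay and not a number. Compound 2 `CCCCCn1nc(C(=O)N[C@H]2COc3ccccc3N(C)C2=S)nc1Cc1ccccc1` gives > 100000 nM, again only a limit. Compound 2 therefore stands on (the limit of > 100000 nM in this assay, at which 2 of the 2 values shown sit), with no exact value to start from.

Compound 3 `CC(C)n1nc(C(=O)N[C@H]2COc3ccccc3N(C)C2=S)nc1Cc1ccccc1` keeps the shared core and changes one group: isopropyl in place of pentyl on an aromatic nitrogen. The group is isopropyl in place of pentyl on an aromatic nitrogen, next to the ring atom that bears a benzyl group.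

Among the compounds with values here, the only measured step that bears on this is a step that the two limits leave unreadable from compound 1 to compound 2, which also alters the chain on that nitrogen but gives no size to carry over. The expectation thus rests on the limit shared by the two measured compounds, and no change beyond the usual scatter is expected, in either direction. The estimated move is a number no higher from compound 2 to compound 3 (the limit leaves the size open). For compound 3 the estimated value is 100000 nM, with an expected range from 50000 nM to 200000 nM.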

Compound 3, half-maximal cytotoxic concentration: > 100000 nM
Compound 3 was reported as a limit (the forecaster's own chance of this, stated with the estimate: 85%); the middle value sits exactly at the limit.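

Within the data shown here, compound 1, compound 2 and compound 3 are each reported only as a limit in this assay, and no step among them can be read: the limit of > 100000 nM in this assay, at which 3 of the 3 values shown sit. The compounds shown leave open what exact concentration of each compound the cells tolerate, and whether the chain on the aromatic nitrogen changes it.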